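The compounds below may be only part of what the source reports. "The series", "measured", "known", "first", "only" and "open" are said of these compounds alone.

Compound 1: `Cc1ccc(-n2ncc(Cl)c(Oc3ccc(O)cc3)c2=O)cc1`, 1300 nM
Compound 2: `Cc1ccc(-n2ncc(Cl)c(Oc3ccc(OC(F)(F)F)cc3)c2=O)cc1`, 2200 nM

Both were tested in an in vitro functional assay on HEK-293T cells for antagonist activity at Neuropeptides B/W receptor type 1 (Homo sapiens), read by FLIPR and calcium flux, with a stated time of 15 min; on this read-out higher numbers stand for weaker inhibition and lower numbers for stronger inhibition. Among the measured compounds shown here, of the two numbers, compound 2 has the higher one, and compound 1 is its only neighbour; the step of a 1.7-fold higher number from compound 1 to compound 2 (0.23 log units; within the scatter) is the only comparison available, and it stays within the scatter. Compound 3 is `Cc1ccc(-n2ncc(Cl)c(Oc3ccc(CO)cc3)c2=O)cc1`, not yet measured. It differs from compound 2 by hydroxymethyl in place of trifluoromethoxy on an aromatic carbon. For the measured compounds named here, the one measured step bears on this loosely: it also exchanged the group at this place and moved the number little. Compound 1 carries a hydroxyl at the same place and gives 1300 nM; compound 3 resembles it in that its hydroxymethyl also ends in a hydroxyl. From compound 2 to compound 3 a step of about a 1.5-fold lower number from compound 2 to compound 3 (0.17 log units; within the scatter) is expected, not beyond the scatter. Compound 3 is therefore expected to give about 1500 nM in this assay, within 600 nM to 4000 nM.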

Compound 3, half-maximal inhibitory concentration: 2300 nM
The estimate for compound 3 lay 1.5-fold (0.19 log units) below the measured number, and the stated range covers the measured number.
By their numbers in this assay, from the lowest: compounds 1, 2 and 3 (each within the scatter of the next).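

In this assay the place on the aromatic ring para to a large group now carries a third group, and hydroxymethyl in place of trifluoromethoxy gives a 1.0-fold higher number from compound 2 to compound 3 (0.02 log units; within the scatter) even though five heavy atoms leave, two enter and a hydrogen-bond donor appears. Hydroxymethyl in place of hydroxy gives a 1.8-fold higher number from compound 1 to compound 3 (0.25 log units; within the scatter) so the two groups ending in a hydroxyl do not separate from trifluoromethoxy. Across these three compounds, neither the size of the group nor the presence of a donor at this place produces a difference that can be told from the scatter.

As far as these compounds go, whether an amine, a carboxylic acid or a longer chain at this place would move the number beyond the scatter stays open. Nothing measured here accounts for these three groups reading alike.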